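Removing the chloro from the benzimidazole of compound 2

A few compounds are considered here, and "the series" means these few. Any claim that something is new, unique, unknown or untested is made for them only; others in the source may bear on it.

Compound 2 `C[C@@H]1CN(c2sc(C(F)(F)F)nc2-c2nc3cc(Cl)ccc3[nH]2)CCN1C(=O)Cn1cnc2cccnc21`: 38.5 nM
Compound 1 `Cc1nc(C)n(CC(=O)N2CCN(c3sc(C(F)(F)F)nc3-c3nc4ccc(C5CCOCC5)cc4[nH]3)C[C@H]2C)n1`: 123 nM
Compound 3 `Cc1nc(C)n(CC(=O)N2CCN(c3sc(C(F)(F)F)nc3-c3nc4ccc(OC5COC5)cc4[nH]3)C[C@H]2C)n1`: 1480 nM

Of the compounds shown here, three share the core and have been measured in a functional assay on Venous blood for antagonist activity at C-X-C chemokine receptor type 3 (Homo sapiens), read by flow cytometry, with a stated time of 30 min, in the presence of a further agent that is not named here; on this read-out lower numbers stand for stronger inhibition and higher numbers for weaker inhibition. Compound 2 gives the lowest number of the three in this assay, at 38.5 nM. Its nearest neighbour is compound 1, which gives 123 nM, a gap that lies beyond the scatter; compound 3 lies furthest, at 1480 nM. Going by the values given here, the only single-point step among the measured compounds is a 12-fold higher number from compound 1 to compound 3 (1.08 log units; beyond the scatter), which concerns a substituent on the other end of the benzimidazole and not the change considered here.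

Compound 4 `C[C@@H]1CN(c2sc(C(F)(F)F)nc2-c2nc3ccccc3[nH]2)CCN1C(=O)Cn1cnc2cccnc21` differs from compound 2 in one place: hydrogen in place of chloro on an aromatic carbon. Among the compounds with values here, no measured pair shows the effect of taking off this chloro, so the expectation rests on the general observation that a single small group removed from this ring tends to shift the number modestly. Compound 4 is therefore expected to give a somewhat higher number than compound 2, with the step of a 1.8-fold higher number from compound 2 to compound 4 (0.26 log units; within the scatter) likely near the edge of the scatter. The estimate for compound 4 in this assay is 70 nM, within a range of 25 nM to 200 nM.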

Compound 4, half-maximal inhibitory concentration: 70 nM
Estimate against measurement, compound 4: no gap at the digits printed; measured number inside the range.
By their numbers in this assay, from the lowest: compounds 2, 4 and 1 (each within the scatter of the next, the first and the last beyond it); then compound 3.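

In this assay, the change from 5-chloro-1H-benzimidazol-2-yl to 1H-benzimidazol-2-yl gives a 1.8-fold higher number from compound 2 to compound 4 (0.26 log units; within the scatter), so this chloro can be exchanged for hydrogen without a step that can be told from the scatter. The earlier compounds shown here offered only a 12-fold higher number from compound 1 to compound 3 (1.08 log units; beyond the scatter), a large step for a different change, and gave no reading of this aromatic carbon; here the unsubstituted compound 4 gives 70 nM. No measurement is available that would explain this result.

The compounds shown leave open how larger or different groups at this aromatic carbon, such as a methoxy, a nitrile or an amine, would read. They also leave open whether the same exchange of chloro for hydrogen gives a comparable step when the rest of the molecule carries another amide side chain.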